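The source may report more compounds than this note shows. Statements on the series, on what has been measured and on what is new or still open speak of the compounds shown alone.

In an assay on HEK293 cells for displacement of a labelled ligand from Neuronal acetylcholine receptor; alpha4/beta2 (Homo sapiens), read by scintillation counting, with a stated time of 120 min (a lower number here means a stronger inhibitor, a higher number a weaker inhibitor), compound 1 `c1ccc(COc2cccc(-c3cn(C4CN5CCC4CC5)nn3)c2)cc1` gives 668 nM, while compound 2 `FCCOc1cccc(-c2cn([C@H]3CN4CCC3CC4)nn2)c1` gives 7050 nM, the higher of the two numbers, and the gap to compound 1 lies beyond the scatter. Compound 3 `FCCOc1cccc(-c2cn(C3CN4CCC3CC4)nn2)c1` differs from compound 2 only in that (the two compounds have the same atoms and bonds; at least one stereo element is drawn with a configuration in one of them and without one in the other: 1 of 3 stereo elements differ; a stereocentre at a saturated ring carbon is drawn R in compound 2 and without a configuration in compound 3). The two share every atom and bond; the step from compound 2 to compound 3 in this assay is expected to be a 1.1-fold higher number from compound 2 to compound 3 (0.03 log units; within the scatter), that is, no change beyond the scatter in either direction. Compound 3 is therefore estimated at 7500 nM, with a range from 2500 nM to 22000 nM.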

Compound 3, inhibition constant: 1960 nM
Compound 3: middle estimate off by 3.8-fold (0.58 log units), on the high side; measured number below the stated range.
By their numbers in this assay, from the lowest: compound 1; then compound 3; then compound 2.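

In this assay, a 3.6-fold lower number from compound 2 to compound 3 (0.56 log units; beyond the scatter) shows that the drawn configuration at this saturated ring carbon matters, with the R form giving the higher number. The two compounds are separated by nothing else: the fact that one of compounds 2 and 3 is drawn with a defined configuration and the other without, at the place where they differ With the configuration undefined in both compounds, fluoromethyl in place of phenyl gives a 2.9-fold higher number from compound 1 to compound 3 (0.47 log units; beyond the scatter), a smaller gap than the values of compound 1 and compound 2 show. The compounds shown leave open how the form drawn S at this stereocentre behaves. They also leave open whether an amine or a longer chain in place of fluoromethyl would shift the number.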